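Swapping One Group on the Amide Carbonyl

The source may hold more compounds than are shown below. What is called first, only, known or untested is meant among the compounds shown, and "the series" means these compounds.

Compound 1 `C#CCOc1ccc(C(=O)Nc2cc3ccc(OC4CCN(C)CC4)c(C)c3oc2=O)cc1CC=C(C)C` gives 1120 nM
Compound 2 `CC(=O)Oc1ccc(C(=O)Nc2cc3ccc(OC4CCN(C)CC4)c(C)c3oc2=O)cc1` gives 1620 nM

Both numbers come from a functional assay on MCF7 cells (Homo sapiens) for antiproliferative activity; on this read-out lower numbers stand for stronger inhibition and higher numbers for weaker inhibition. Repeating such a measurement never returns quite the same number, so small gaps carry no meaning. Compound 2, at 1620 nM, lies within that scatter of compound 1 at 1120 nM, and the two cannot be told apart.

The next compound changes one place. Compound 3 `Cc1c(OC2CCN(C)CC2)ccc2cc(NC(=O)c3ccc(O)c(Cl)c3)c(=O)oc12` carries 3-chloro-4-hydroxyphenyl in place of 4-acetoxyphenyl on a carbonyl carbon, with the rest of compound 2 kept: 3-chloro-4-hydroxyphenyl in place of 4-acetoxyphenyl on a carbonyl carbon.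

Among the compounds with values here, no measured pair differs in just one place, so the data offer no direct guide to the size of such a change in this assay. Within the data shown here, the only hint is that compound 2 at 1620 nM and compound 1 at 1120 nM sit within the scatter of each other. On that thin basis, no step beyond the scatter is expected, and no direction can be named. The estimated step is a 1.1-fold lower number from compound 2 to compound 3 (0.03 log units; within the scatter). Among the measured compounds shown here, with only two measured compounds to draw on, the range has to stay wide. The expected value for compound 3 is 1500 nM, with an estimated range from 500 nM to 5000 nM.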

Compound 3, half-maximal inhibitory concentration: 1480 nM
Compound 3: the middle estimate sits 1.0-fold (0.01 log units) above what was measured; measured number inside the range.
By their numbers in this assay, from the lowest: compounds 1, 3 and 2 (each within the scatter of the next).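

In this assay replacing 4-acetoxyphenyl with 3-chloro-4-hydroxyphenyl, on a carbonyl carbon whose other neighbour is an amide-type nitrogen, gives a 1.1-fold lower number from compound 2 to compound 3 (0.04 log units; within the scatter) and so cannot be told apart from no change at all. Within the data shown here, this is the first pair that differs in one place, and it shows that this particular exchange leaves no readable mark on the number, even though the entering group brings a chlorine atom and a hydrogen-bond donor that the leaving group lacks. No measurement shown here explains why these two compounds sit so close together.

Two things changed at once in this swap, with the acetoxy group gone and the chlorine and hydroxyl present together, so a group such as plain 4-hydroxyphenyl or 3-chlorophenyl would be needed to separate their parts. As far as these compounds go, it also remains open whether this place would respond to a very different group, such as an amine or a carboxylic acid on the phenyl ring, since one exchange within the scatter says little about the full range of possible groups.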